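The compounds below may be only part of what the source reports. "The series", "measured", "known", "first", "only" and "open" are said of these compounds alone.

Two compounds have been measured so far in an ADME assay on HFF cells (Homo sapiens) for cytotoxicity, read by MTT assay, with a stated time of 72 h; on this read-out higher numbers stand for weaker inhibition and lower numbers for stronger inhibition:

- Compound 1 `COc1ccccc1-c1cn(C[C@H](O)[C@H]2OC(=O)C(OCc3ccccc3)=C2OCc2ccccc2)nn1` gives 50 nM as its value
- Compound 2 `O=C1O[C@H]([C@@H](O)Cn2cc(-c3cc(F)cc(F)c3)nn2)C(OCc2ccccc2)=C1OCc1ccccc1` gives > 100000 nM as a limit of the assay, not a number

Compound 2 stands at the high end of the numbers shown: this is the limit of > 100000 nM in this assay, at which 1 of the 2 values shown sits, and no exact number is known for it. Compound 3 `O=C1O[C@H]([C@@H](O)Cn2cc(CCO)nn2)C(OCc2ccccc2)=C1OCc1ccccc1` keeps the shared core and carries 2-hydroxyethyl in place of 3,5-difluorophenyl on an aromatic carbon of the five-membered aromatic ring with 3 nitrogen.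

Among the compounds with values here, one measured step bears on this place: an at least 2000-fold higher number from compound 1 to compound 2 (3.30 log units; beyond the scatter), where 3,5-difluorophenyl replaced 2-methoxyphenyl on the same aromatic carbon. That large step, beyond the scatter, shows that a swap here can move the number a long way in this assay. However, it joins two groups that both hold a ring, and no measured compound has a group without a ring here.

Within the data shown here, the only low value belongs to compound 1 at 50 nM, with 2-methoxyphenyl, which compound 3 lacks. Compound 3 is therefore expected to stay near compound 2, with no step beyond the scatter expected, though lower numbers remain possible. The expected step is an at least 1.4-fold lower number from compound 2 to compound 3 (0.15 log units; that floor lies within the scatter) as an estimate. The estimated value for compound 3 is 70000 nM, expected within 5000 nM to 200000 nM, and the assay may well report only a limit again.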

Compound 3, half-maximal inhibitory concentration: 58500 nM
The estimate for compound 3 lay 1.2-fold (0.08 log units) above the measured number, and the stated range covers the measured number.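

In this assay, the change to 2-hydroxyethyl gives a 1200-fold higher number from compound 1 to compound 3 (3.07 log units; beyond the scatter), so a group with no ring on this aromatic carbon also ends far from compound 1, and the earlier large step was not special to 3,5-difluorophenyl. Compound 2 has only a limit of the assay, not a number, so the step to the new group, an at least 1.7-fold lower number from compound 2 to compound 3 (0.23 log units; that floor lies within the scatter), is a floor within the scatter and does not tell how far apart the two really lie. Among the three compounds, then, two very different groups, one with a six-membered aromatic ring and fluorine and one with neither, both give high numbers, and only 2-methoxyphenyl gives a low one.

The compounds shown leave open whether the low value of compound 1, 50 nM, depends on the methoxy group or on the ring that carries it, which plain phenyl would help to separate. They also leave open how other groups without a ring behave here, such as a longer chain or a chain ending in an amine or a carboxylic acid.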